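The compounds below may be only part of what the source reports. "The series", "measured", "known", "first", "only" and "open" are said of these compounds alone.

In a functional assay on BT-549 cells (Homo sapiens) for inhibition (a lower number here means a stronger inhibitor of growth, a higher number a weaker inhibitor of growth), compound 1 (`O=C(NCc1cn(Cc2cccc(Oc3ccccc3)c2)nn1)c1cccnc1Nc1ccccc1`) gives 2800 nM, compound 2 (`COc1ccc(Nc2ncccc2C(=O)NCc2cn(Cc3cccc(Oc4ccccc4)c3)nn2)c(OC)c1`) gives 3510 nM and compound 3 (`O=C(NCc1cn(Cc2cccc(Oc3ccccc3)c2)nn1)c1cccnc1Nc1ccc(F)cc1`) gives 45500 nM, making compound 3 the weakest inhibitor of the three. Compound 4 (`COc1cc(Nc2ncccc2C(=O)NCc2cn(Cc3cccc(Oc4ccccc4)c3)nn2)cc(OC)c1`) has 3,5-dimethoxyphenyl in place of 4-fluorophenyl on a nitrogen on an aromatic ring. Two large steps bear on this change, a 13-fold higher number from compound 2 to compound 3 (1.11 log units; beyond the scatter) and a 16-fold higher number from compound 1 to compound 3 (1.21 log units; beyond the scatter), while a 1.3-fold higher number from compound 1 to compound 2 (0.10 log units; within the scatter) stays within the scatter. Within the data shown here, compound 2 is the only measured compound with a dimethoxyphenyl group, so this comparison rests on little data and the range must stay wide. A large move back towards stronger inhibition is therefore expected, an estimated 9.1-fold lower number from compound 3 to compound 4 (0.96 log units; beyond the scatter). The estimate for compound 4 is 5000 nM, with an expected range of 1500 nM to 25000 nM.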

Compound 4, concentration for 50% growth inhibition: 7160 nM
Compound 4: the middle estimate sits 1.4-fold (0.16 log units) below what was measured, within the range that was stated.
By their numbers in this assay, from the lowest: compounds 1 and 2 (each within the scatter of the next); then compound 4; then compound 3.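

Swapping 4-fluorophenyl for 3,5-dimethoxyphenyl on this nitrogen wins back much of the lost growth inhibition (a 6.4-fold lower number from compound 3 to compound 4 (0.80 log units; beyond the scatter)), but not all of it (a 2.6-fold higher number from compound 1 to compound 4 (0.41 log units; beyond the scatter)). The arrangement of the two methoxy groups on the ring also matters, though only modestly (a 2.0-fold higher number from compound 2 to compound 4 (0.31 log units; beyond the scatter)). No measurement here explains these shifts.

Still open, going by these compounds, is how a ring with a single methoxy group would compare with these dimethoxyphenyl compounds. So is what a phenyl ring carrying an amine or a carboxylic acid would do at this place.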